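The source may report more compounds than this note shows. Statements on the series, on what has been measured and on what is new or still open speak of the compounds shown alone.

Working notes on the series.

Compound 1 `O=C(Nc1ccncc1)Nc1cc(-c2cncnc2)cc(C(F)(F)F)c1` carries a pyridin-4-yl on the amide-type nitrogen and is the reference for the first core. In a functional assay on SMMC-7721 cells (Homo sapiens) for inhibition, read by MTT assay, with a stated time of 48 h (a higher number here means a weaker inhibitor, a lower number a stronger inhibitor), compound 1 gives 3730 nM. Compound 3 `O=C(Nc1cc(-c2cncnc2)cc(C(F)(F)F)c1)Nc1nccs1` differs from it by the change (1,3-thiazol-2-yl in place of pyridin-4-yl on an amide-type nitrogen), and in this assay compound 3 gives 29700 nM. The step of an 8.0-fold higher number from compound 1 to compound 3 (0.90 log units; beyond the scatter) is therefore a clear weakening, not lost in the scatter.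

Compound 2 `COc1ccc(-c2ccc(OC(F)(F)F)c(NC(=O)Nc3ccncc3)c2)cn1` belongs to a second core; how the two cores differ is not broken down here. In this assay compound 2 gives "not determined" (no result reported), so the second core has no measured anchor.

Compound 4 `COc1ccc(-c2ccc(OC(F)(F)F)c(NC(=O)Nc3nccs3)c2)cn1` is the unmeasured partner of compound 2 and differs from it by 1,3-thiazol-2-yl in place of pyridin-4-yl on an amide-type nitrogen, the same kind of change as from compound 1 to compound 3, placed on an amide-type nitrogen whose other neighbours are a carbonyl carbon in both pairs. Among the compounds shown this change occurs twice, once measured and once pending.

The expectation for compound 4 rests on a single measured step, an 8.0-fold higher number from compound 1 to compound 3 (0.90 log units; beyond the scatter), and on the absence of a value for compound 2, so it is loosely held. Compound 4 is expected to be a weak inhibitor in this assay, estimated around 30000 nM, with a plausible range from 6000 nM to 120000 nM, and a real chance that only a limit is reported.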

Compound 4, half-maximal inhibitory concentration: 44100 nM
The estimate for compound 4 lay 1.5-fold (0.17 log units) below the measured number, within the range that was stated.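

Going by these compounds alone, no new step can be read: in this assay compound 4 gives 44100 nM, but compound 2 has no single number to pair with it. No measurement shown offers an explanation for these values.

The compounds shown leave open whether 1,3-thiazol-2-yl in place of pyridin-4-yl changes inhibition on the core of compound 2 as it does on the core of compound 1.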